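The compounds below may be only part of what the source reports. "The series", "measured", "known", "first", "only" and "open" are said of these compounds alone.

In a functional assay on SK-OV-3 cells (Homo sapiens) for antiproliferative activity, read by MTT assay, with a stated time of 72 h (on this read-out lower numbers stand for stronger inhibition and higher numbers for weaker inhibition), compound 1 `COc1cccc(-c2cccc(NC(=O)CCc3ccc4c(c3)COB4O)c2)c1` gives > 100000 nM, which is a limit of the assay and not a number. Among the measured compounds shown here, compound 2 `COc1cc(OC)cc(-c2cccc(NC(=O)CCc3ccc4c(c3)COB4O)c2)c1` gives 93000 nM, the only true number so far. For the measured compounds named here, the one measured step, an at least 1.0-fold lower number from compound 1 to compound 2 (0.03 log units; that floor lies within the scatter), comes with methoxy in place of hydrogen on an aromatic carbon. It rests on (the limit of > 100000 nM in this assay, at which 1 of the 2 values shown sits), so it gives only a floor for the size of that change.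

Compound 3 `COc1cc(OC)cc(-c2cccc(NC(=O)CCc3cccc4c3COB4O)c2)c1` has the same atoms as compound 2, joined differently: a group of 10 heavy atoms (7 carbon, 1 boron, 2 oxygen; one five-membered non-aromatic ring with 2 hetero atoms, one six-membered aromatic ring of carbon only) in place of a group of 10 heavy atoms (7 carbon, 1 boron, 2 oxygen; one five-membered non-aromatic ring with 2 hetero atoms, one six-membered aromatic ring of carbon only), on a saturated chain carbon, two bonds along the chain from a carbonyl carbon. The measured step concerns a different kind of change, so it offers no direct guide to this one. With only compound 2 at 93000 nM as a numerical starting point, no clear shift can be predicted in either direction. The expected change is a 1.2-fold lower number from compound 2 to compound 3 (0.07 log units; within the scatter), which means no step beyond the scatter, although a real change cannot be ruled out. There is also a fair chance of another limit rather than a number. For compound 3, the estimated value is 80000 nM, with an expected range from 25000 nM to 180000 nM.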

Compound 3, half-maximal inhibitory concentration: 88000 nM
The estimate for compound 3 lay 1.1-fold (0.04 log units) below the measured number, within the range that was stated.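

Among the compounds shown here, this is the first step between two true numbers, so it has a real size and not just a floor. Joining the same atoms of the boron-bearing group differently, on the saturated chain carbon two bonds along the chain from a carbonyl carbon, gives a 1.1-fold lower number from compound 2 to compound 3 (0.02 log units; within the scatter) in this assay. For compound 2 and compound 3, then, how this group is joined makes no difference beyond the scatter, whereas the earlier methoxy step gave only a floor because compound 1 stands at a limit of the assay and not at a number: the limit of > 100000 nM in this assay, at which 1 of the 3 values shown sits.

On these data alone, what stays open is whether anything at this place can move the number beyond the scatter, for example a carboxylic acid or an amine in place of the boron-bearing group, or a longer chain between that group and the carbonyl. For the compounds shown here, it also stays open whether the rearranged group would give the same result on the core of compound 1, with its single methoxy, since only the pair of compound 2 and compound 3 speaks to this change.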